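Swapping Thiophene for Thiazole in a Cytotoxicity Series

This account rests on a few compounds, and the source may have more. Where it says the series, first, only, none or still open, it means among the compounds named here.

The measured compounds and their values:

compound 1, `CCCCc1csc(CN[C@@H]2C[C@H]3C[C@@H]([C@H]2C)C3(C)C)c1`: 12500 nM
compound 2, `C[C@H]1[C@H](NCc2cccs2)C[C@H]2C[C@@H]1C2(C)C`: 25000 nM
compound 3, `C[C@H]1[C@H](NCc2ccc(-c3ccc(Br)s3)s2)C[C@H]2C[C@@H]1C2(C)C`: 780 nM

All three were tested in an ADME assay on MDCK cells (Canis lupus familiaris) for cytotoxicity, read by microscopy, with a stated time of 48 h; a higher number here means that more compound is tolerated, a lower number that less compound is tolerated. Compound 2 has the highest of the three numbers. Its nearest neighbour is compound 1, since the step of a 2.0-fold higher number from compound 1 to compound 2 (0.30 log units; within the scatter) lies within the scatter; compound 3 is the furthest away, the step of a 32-fold lower number from compound 2 to compound 3 (1.51 log units; beyond the scatter) being large and well beyond the scatter.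

The next compound, compound 4 `C[C@H]1[C@H](NCc2nccs2)C[C@H]2C[C@@H]1C2(C)C`, differs from compound 2 in one place: 1,3-thiazol-2-yl in place of thiophen-2-yl on a saturated chain carbon bound to an amine nitrogen.

Neither measured step directly covers such an exchange of one ring for another. The step from compound 1 to compound 2 shows that removing butyl from the aromatic ring stays within the scatter, while the step from compound 2 to compound 3 shows that attaching 5-bromothiophen-2-yl lowers the tolerated concentration strongly. The change to compound 4 adds no such appendage; the group that enters matches the one that leaves in what is counted. It is therefore expected that compound 4 shows no step beyond the scatter, that is no change at the digits printed from compound 2 to compound 4 (within the scatter), in this assay.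

Compound 4 is thus estimated to give 25000 nM, expected to fall between 12500 nM and 50000 nM.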

Compound 4, minimum cytotoxic concentration: > 100000 nM
Compound 4: a limit, no number; the forecaster's own chance of this, stated with the estimate: 20%; middle value at least 4.0-fold (0.60 log units) from the limit.
By their numbers in this assay, from the lowest: compound 3; then compounds 1 and 2 (each within the scatter of the next). At a limit, above all of these: compound 4.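

In this assay, the step to the thiazole gives an at least 4.0-fold higher number from compound 2 to compound 4 (0.60 log units; beyond the scatter), which shows that this place on a saturated chain carbon bound to an amine nitrogen responds to an exchange of one ring for another, even when the heavy-atom count stays the same and a ring nitrogen stands where thiophen-2-yl had a carbon. Compound 4 gives > 100000 nM, which is a limit of the assay and not a number: the limit of > 100000 nM in this assay, at which 1 of the 4 values shown sits. The earlier steps had either stayed within the scatter, on removing butyl, or led strongly downward, on adding 5-bromothiophen-2-yl, so this is the first single change shown to move the number upward beyond the scatter, and it does so without any added appendage.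

The compounds shown leave open how far compound 4 lies beyond its limit, and whether the same exchange would raise the number when butyl or 5-bromothiophen-2-yl is also present on the ring. They also leave open how other rings would behave at this place, such as a furan, an oxazole or a pyridine, or a plain phenyl ring.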